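Swapping the thiadiazole for a triazole on the sulfur

The source may hold more compounds than are shown below. What is called first, only, known or untested is meant among the compounds shown, and "the series" means these compounds.

For the measured compounds named here, compound 1 `Nc1nnc(SC[C@H]2O[C@@H](OCc3noc(-c4ccc(Cl)cc4)n3)[C@@H]3OC4(CCCC4)O[C@@H]32)s1` is the only compound here with a number in a functional assay on A549 cells (Homo sapiens) for antiproliferative activity, read by sulforhodamine B assay, with a stated time of 48 h (a lower number here means a stronger inhibitor of growth, a higher number a weaker inhibitor of growth), where compound 1 gives 15000 nM. Compound 2 `CC1(C)O[C@H]2[C@H](OCc3noc(-c4ccc([N+](=O)[O-])cc4)n3)O[C@H](CSc3nnc(N)s3)[C@H]2O1` reaches only the limit of this assay, giving > 100000 nM. Compound 3 `Clc1ccc(-c2nc(CO[C@@H]3O[C@H](CSc4ncn[nH]4)[C@H]4OC5(CCCC5)O[C@@H]34)no2)cc1` is not yet measured; it differs from compound 1 in one place (1H-1,2,4-triazol-5-yl in place of 5-amino-1,3,4-thiadiazol-2-yl on a sulfur). Going by the values given here, with no measured step of this kind to lean on, a small drop in potency is expected, within or slightly beyond the usual scatter, so the step of a 1.5-fold higher number from compound 1 to compound 3 (0.17 log units; within the scatter) is an estimate. Compound 3 is expected to give about 22000 nM, between 6000 nM and 80000 nM.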

Compound 3, concentration for 50% growth inhibition: 13000 nM
Compound 3: middle estimate off by 1.7-fold (0.23 log units), on the high side, and the stated range covers the measured number.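

In this assay the step of a 1.2-fold lower number from compound 1 to compound 3 (0.06 log units; within the scatter) shows that the ring on this sulfur can change from 5-amino-1,3,4-thiadiazol-2-yl to 1H-1,2,4-triazol-5-yl with no change beyond the scatter. This change removes the amino group and the ring sulfur together, so neither is required here for this level of growth inhibition. Nothing measured here explains this result. Still open, as far as these compounds go, is whether a 1,2,4-triazole carrying an amino group would read the same, and whether a carboxylic acid in place of the ring would keep this activity.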